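Ring size change from compound 1 to compound 3

The source may report more compounds than this note shows. Statements on the series, on what has been measured and on what is new or still open speak of the compounds shown alone.

Measured in a functional assay on A549 cells (Homo sapiens) for cytotoxicity, read by MTT assay, with a stated time of 72 h; on this read-out lower numbers stand for an effect already at smaller amounts and higher numbers for an effect only at larger amounts of compound:
compound 1 `COc1ccc(Nc2cc(C3CCCCC3)oc(=O)c2)cc1`: 4.62 uM
compound 2 `COc1ccc(Nc2cc(-c3ccc4ccccc4c3)oc(=O)c2)cc1`: 0.15 uM

Compound 1 holds the highest of the two numbers; compound 2 stands apart from it, beyond the scatter. Compound 3 `COc1ccc(Nc2cc(C3CCCC3)oc(=O)c2)cc1` differs from compound 1 by cyclopentyl in place of cyclohexyl on an aromatic carbon. Within the data shown here, no measured pair shows this change, so only a small step is expected, at most a drift towards a higher number and nothing beyond the scatter. The expected step is a 1.3-fold higher number from compound 1 to compound 3 (0.11 log units; within the scatter). Compound 3 is estimated at 6 uM, between 2 uM and 18 uM.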

Compound 3, concentration for half-maximal effect: 5.42 uM
The estimate for compound 3 lay 1.1-fold (0.04 log units) above the measured number; the range from low to high includes it.
By their numbers in this assay, from the lowest: compound 2; then compounds 1 and 3 (each within the scatter of the next).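

In this assay, cyclopentyl in place of cyclohexyl on the aromatic carbon next to the ring oxygen gives a 1.2-fold higher number from compound 1 to compound 3 (0.07 log units; within the scatter) at this position. The ring size of the saturated carbon ring, across these two sizes, therefore does not separate the two compounds, a point the comparison of compound 1 with compound 2 could not show. No measurement bearing on the reason for this result is at hand.

Still open, going by these compounds, is whether cyclopropyl, an open chain such as isopropyl, or a cyclohexyl ring carrying an amine stays with compound 1 and compound 3 or moves towards compound 2.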